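From 2,6-dichlorophenyl to 2,6-difluorophenyl at the assay limit

The source may report more compounds than this note shows. Statements on the series, on what has been measured and on what is new or still open speak of the compounds shown alone.

In an ADME assay on TZM cells (Homo sapiens) for cytotoxicity, read by WST assay, with a stated time of 2 days (on this read-out higher numbers stand for lower toxicity in this test and lower numbers for higher toxicity in this test), compound 1 `Cc1c(Cc2c(Cl)cccc2Cl)nc(N(C)Cc2ccc(N3CCN(C)CC3)cc2)[nH]c1=O` gives 3200 nM. Compound 2 `Cc1c(C(C)c2c(Cl)cccc2Cl)nc(N(C)Cc2ccc(N3CCN(C)CC3)cc2)[nH]c1=O` gives > 10000 nM, which is a limit of the assay and not a number. The move between these two compounds is an at least 3.1-fold higher number from compound 1 to compound 2 (0.49 log units; beyond the scatter), so compound 2 stands at the less toxic end of the two values measured.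

Compound 3 `Cc1c(C(C)c2c(F)cccc2F)nc(N(C)Cc2ccc(N3CCN(C)CC3)cc2)[nH]c1=O` keeps the methyl of compound 2 but carries 2,6-difluorophenyl in place of 2,6-dichlorophenyl on a saturated chain carbon bound to an aromatic carbon and a saturated chain carbon. Going by the values given here, the only measured step nearby is an at least 3.1-fold higher number from compound 1 to compound 2 (0.49 log units; beyond the scatter), and it involves a different change. Among the compounds with values here, no measured pair shows this swap, so the best guess in this assay is no shift beyond the scatter. The estimated step is a number no higher from compound 2 to compound 3 (the limit leaves the size open). For compound 3 the expected value is 10000 nM, with an estimated range of 4000 nM to 30000 nM.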

Compound 3, half-maximal cytotoxic concentration: 26200 nM
Compound 3: middle estimate off by 2.6-fold (0.42 log units), on the low side; the measured number falls inside the stated range.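

For compound 2, > 10000 nM is a limit of the assay and not a number, so the step from compound 2 to compound 3 cannot be read: the limit of > 10000 nM in this assay, at which 1 of the 3 values shown sits.

Compound 3 does give a measured number, so the full change on this aromatic carbon, from 2,6-dichlorobenzyl to 1-(2,6-difluorophenyl)ethyl, can now be sized as an 8.2-fold higher number from compound 1 to compound 3 (0.91 log units; beyond the scatter). This shows that a compound carrying the added methyl and 2,6-difluorophenyl together stays on the less toxic side of compound 1.

On these data alone, what stays open is how much of that step belongs to the methyl and how much to the swap of chlorine for fluorine. A 2,6-difluorobenzyl group on the shared core would separate the two changes, and it is not among the compounds shown.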